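The source may hold more compounds than are shown below. What is called first, only, known or untested is meant among the compounds shown, and "the series" means these compounds.

Series notes. For the measured compounds named here, in an assay on cells for displacement of a labelled ligand from metabotropic glutamate receptor 2 (Homo sapiens), read by scintillation counting, with a stated time of 60 min (on this read-out lower numbers stand for stronger inhibition and higher numbers for weaker inhibition), compound 3 `FC(F)(F)c1c(-c2ccc(NC3CCOCC3)c(Cl)c2)ccn2c(CC3CC3)nnc12` gives 5.01 nM, the lowest of the three numbers measured so far. Compound 1 `CC(C)Nc1ccc(-c2ccn3c(CC4CC4)nnc3c2C(F)(F)F)cc1F` gives 8.91 nM in this assay, a gap to compound 3 that lies within the scatter, so no order between these two is claimed. Going by the values given here, compound 2 `Clc1cc(-c2ccn3c(CC4CC4)nnc3c2Cl)ccc1NC1CCOCC1` gives 38.9 nM in this assay; the step of a 7.8-fold lower number from compound 2 to compound 3 (0.89 log units; beyond the scatter) is the only single-change step in the set. Among the compounds with values here, compound 1 and compound 3 differ in two places, so their two values are simply noted side by side and no step is drawn between them.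

Compound 4 `O[C@H]1CC[C@H](Oc2ccc(-c3ccn4c(CC5CC5)nnc4c3C(F)(F)F)cc2Cl)CC1` has not yet been measured in this assay. It differs from compound 3 by (4-hydroxycyclohexyl)oxy in place of (oxan-4-yl)amino on an aromatic carbon. Within the data shown here, no measured step bears on this change: the one recorded step concerns a different position and a different kind of exchange, and nothing in the set varies the amino-linked group on its own. Among the measured compounds shown here, the expectation for compound 4 in this assay therefore rests on no precedent, and a step of a 2.0-fold higher number from compound 3 to compound 4 (0.30 log units; within the scatter) is estimated, with a deliberately wide range around it. For compound 4 the estimate in this assay is 10 nM, expected to fall between 2.5 nM and 40 nM.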

Compound 4, inhibition constant: 1.91 nM
Compound 4: middle estimate off by 5.2-fold (0.72 log units), on the high side, and the stated range ends above it.
By their numbers in this assay, from the lowest: compound 4; then compounds 3 and 1 (each within the scatter of the next); then compound 2.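

The position on the aromatic carbon ortho to a chloro group now has its first single-change step in this assay, where (4-hydroxycyclohexyl)oxy in place of (oxan-4-yl)amino gives a 2.6-fold lower number from compound 3 to compound 4 (0.42 log units; beyond the scatter). This position therefore tolerates a switch from a nitrogen link to an oxygen link together with a change from a ring holding one hetero atom to a carbon-only ring bearing a hydroxyl group and two defined stereocentres, and the number falls rather than rises, while the two groups carry the same counts of hydrogen-bond donors and acceptors. No measurement here bears on the reason for this step.

From the compounds shown here alone, the exchange alters the link atom, the ring and the hydroxyl group at once, so which of these parts carries the step stays open; an (oxan-4-yl)oxy group, a (4-hydroxycyclohexyl)amino group or a plain cyclohexyloxy group would pull them apart. The compounds shown also leave open how the other stereoisomer of the (4-hydroxycyclohexyl)oxy group would read, and whether the step holds with chloro instead of trifluoromethyl on the core.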